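The compounds below may be only part of what the source reports. "The series", "measured", "known", "first", "only" and "open" are said of these compounds alone.

Measured in an assay on isolated protein for displacement of a labelled ligand from metabotropic glutamate receptor 5 (Homo sapiens), with a stated time of 60 min, tested at 1 uM; on this read-out lower numbers stand for less inhibition and higher numbers for more inhibition at the one concentration tested (going by the name of the read-out):
compound 1 `Cc1cc(C)cc(S(=O)(=O)c2cnc3ccc(C)cc3c2N2CCC(C)CC2)c1` gives 80%
compound 2 `Cc1ccc2ncc(S(=O)(=O)c3ccc(C)c(Cl)c3)c(N3CCC(C)CC3)c2c1` gives 91%
compound 3 `Cc1ccc2ncc(S(=O)(=O)c3cccc(F)c3)c(N3CCC(C)CC3)c2c1` gives 94%

Compound 3 holds the highest of the three numbers; compound 2 sits nearest, within the scatter, while compound 1 sits furthest, beyond it. Compound 4 `Cc1ccc(S(=O)(=O)c2cnc3ccc(C)cc3c2N2CCC(C)CC2)cc1` is not yet measured. Its change from compound 3: 4-methylphenyl in place of 3-fluorophenyl on a sulfonyl sulfur. Among the measured compounds shown here, two measured steps bear on this position: a number 14 percentage points higher from compound 1 to compound 3 (beyond the scatter), and a number 3 percentage points higher from compound 2 to compound 3 (within the scatter). The group of compound 1, which also carried methyls, gave the lowest number; the entering 4-methylphenyl keeps a methyl but loses the fluorine of compound 3. A small downward step is therefore expected, probably within the scatter: a number 6 percentage points lower from compound 3 to compound 4 (within the scatter). Compound 4 is estimated at 88%, range 78% to 96%.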

Compound 4, a percentage reported as inhibition, at one concentration (the size of the read-out at that concentration, not a potency): 82%
The estimate for compound 4 lay 6 percentage points above the measured number, and the stated range covers the measured number.
By their numbers in this assay, from the lowest: compounds 1, 4, 2 and 3 (each within the scatter of the next, the first and the last beyond it).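

In this assay, 4-methylphenyl in place of 3-fluorophenyl on the sulfonyl sulfur gives a number 12 percentage points lower from compound 3 to compound 4 (beyond the scatter), so a ring carrying a single methyl does not hold the number of the fluorinated ring. Loss of the chloro gives a number 9 percentage points lower from compound 2 to compound 4 (within the scatter), and 4-methylphenyl in place of 3,5-dimethylphenyl gives a number 2 percentage points higher from compound 1 to compound 4 (within the scatter), which places the two methyl-only rings together, although compound 2 stays within the scatter of both compound 3 and compound 4.

Nothing available explains these steps. Open, from the compounds shown here alone, is how a methoxy group or an amine on this ring would read.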